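The source may report more compounds than this note shows. Statements on the series, on what has been measured and on what is new or still open speak of the compounds shown alone.

Series notes. Compound 1 `Cc1cc(NC(=O)c2cc([N+](=O)[O-])ccc2Cl)cc(-c2nc3ccccc3s2)c1O`, compound 2 `Cc1ccc(-c2nc3ccccc3s2)cc1NC(=O)c1cc([N+](=O)[O-])c(N2CCCCC2)cc1Cl` and compound 3 `O=C(Nc1ccc(O)c(-c2nc3ccccc3s2)c1)c1cc([N+](=O)[O-])ccc1Cl` have been run in an ADME assay on HEK293 cells (Homo sapiens) for cytotoxicity, with a stated time of 72 h; a lower number here means that less compound is needed, a higher number that more compound is needed for the effect. In this assay compound 1 returns only a limit, > 25000 nM. Compound 2 likewise returns only a limit in this assay, > 25000 nM. Compound 3 also stands at a limit in this assay, > 25000 nM, so its standing can only be read against two further limits. Going by the values given here, the single measured one-place change, a step that the two limits leave unreadable from compound 1 to compound 3, is consequently not readable in size.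

The next compound, compound 4 `O=C(Nc1ccc(F)c(-c2nc3ccccc3s2)c1)c1cc([N+](=O)[O-])ccc1Cl`, differs from compound 3 by fluoro in place of hydroxy on an aromatic carbon. Among the compounds with values here, no measured step covers this change directly. All that bears on it is the limit of > 25000 nM in this assay, at which 3 of the 3 values shown sit, which every value obtained so far shares. The step that the limit leaves unreadable from compound 3 to compound 4 is therefore expected to show no movement beyond the scatter, with compound 4 expected to remain at the limit. Compound 4 is thus estimated at 30000 nM in this assay, within a range from 15000 nM to 100000 nM.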

Compound 4, half-maximal effective concentration: > 25000 nM
Compound 4: only a limit was reported (the forecaster's own chance of this, stated with the estimate: 85%); the middle value lies beyond the limit too.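

No step can be read between compound 3 and compound 4 in this assay, as both stand at a limit: the limit of > 25000 nM in this assay, at which 4 of the 4 values shown sit. The compounds shown leave open at what concentration any of them would reach the effect, and whether any one-place change alters it.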